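This account rests on a few compounds, and the source may have more. Where it says the series, first, only, none or still open, it means among the compounds named here.

Compound 1, `Cn1ncc(Cl)c1-c1cc(C(=O)N[C@@H]2CN[C@H](CC(=O)NC3CC3)C[C@H]2c2ccc(Cl)c(Cl)c2)oc1Cl`, gives 580 nM in a functional assay on OVCAR-8 cells (Homo sapiens) for antiproliferative activity; a lower number here means a stronger inhibitor, a higher number a weaker inhibitor. Compound 2, `C=CC[C@@H]1C[C@@H](c2ccc(Cl)c(Cl)c2)[C@H](NC(=O)c2cc(-c3c(Cl)cnn3C)c(Cl)o2)CN1`, gives 990 nM. Compound 3, `Cn1ncc(Cl)c1-c1cc(C(=O)N[C@@H]2CN[C@H](CCN3CCCC3)C[C@H]2c2ccc(Cl)c(Cl)c2)oc1Cl`, gives 1840 nM.

Compound 3 thus has the highest number of the three: it sits a 1.9-fold higher number from compound 2 to compound 3 (0.27 log units; within the scatter) and a 3.2-fold higher number from compound 1 to compound 3 (0.50 log units; beyond the scatter). Compound 4, `COCC[C@@H]1C[C@@H](c2ccc(Cl)c(Cl)c2)[C@H](NC(=O)c2cc(-c3c(Cl)cnn3C)c(Cl)o2)CN1`, differs from compound 3 in one place: methoxy in place of pyrrolidin-1-yl on a saturated chain carbon, two bonds along the chain from a saturated ring carbon. Among the compounds with values here, no measured step swaps these two groups directly. The steps that touch this position are a 1.7-fold higher number from compound 1 to compound 2 (0.23 log units; within the scatter) and a 1.9-fold higher number from compound 2 to compound 3 (0.27 log units; within the scatter), both small, and a 3.2-fold higher number from compound 1 to compound 3 (0.50 log units; beyond the scatter), which is modest. Within the data shown here, since every change at this position so far moved the number only slightly, a move back toward the numbers of compounds 1 and 2 is expected for compound 4, giving a 1.8-fold lower number from compound 3 to compound 4 (0.26 log units; within the scatter). Compound 4 is therefore estimated at 1000 nM, with a range from 400 nM to 2500 nM.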

Compound 4, half-maximal inhibitory concentration: 1060 nM
Compound 4: the middle estimate sits 1.1-fold (0.03 log units) below what was measured; the measured number falls inside the stated range.
By their numbers in this assay, from the lowest: compounds 1, 2, 4 and 3 (each within the scatter of the next, the first and the last beyond it).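

In this assay, replacing pyrrolidin-1-yl with the smaller, ring-free methoxy gives a 1.7-fold lower number from compound 3 to compound 4 (0.24 log units; within the scatter), so this position does not need that ring or its nitrogen to keep a number in this range. Methoxymethyl also matches vinyl, with a 1.1-fold higher number from compound 2 to compound 4 (0.03 log units; within the scatter), and cyclopropylcarbamoyl, with a 1.8-fold higher number from compound 1 to compound 4 (0.26 log units; within the scatter). Across these four side chains, only the gap between compound 1 and compound 3 lies beyond the scatter. Nothing available explains why such different groups read so alike. As far as these compounds go, whether a primary amine, a carboxylic acid or a longer chain here would move the number remains open.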